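Methoxy, methyl, dimethylamino, and now methylsulfanyl on a shared core

The source may report more compounds than this note shows. Statements on the series, on what has been measured and on what is new or still open speak of the compounds shown alone.

Compound 1 `COc1ncnc2c1c(-c1ccsc1)cn2[C@@H]1O[C@H](CO)[C@@H](O)[C@H]1O`: 5170 nM
Compound 2 `Cc1ncnc2c1c(-c1ccsc1)cn2[C@@H]1O[C@H](CO)[C@@H](O)[C@H]1O`: > 20000 nM
Compound 3 `CN(C)c1ncnc2c1c(-c1ccsc1)cn2[C@@H]1O[C@H](CO)[C@@H](O)[C@H]1O`: > 20000 nM

In a functional assay on A549 cells (Homo sapiens), read by MTT assay, with a stated time of 72 h (on this read-out higher numbers stand for weaker inhibition and lower numbers for stronger inhibition), compound 1 gives 5170 nM. For compound 2 the assay reports only a limit, > 20000 nM. For compound 3 the assay likewise reports only a limit, > 20000 nM. Compound 3 therefore stands at the weaker end of the three, at the limit where two of the three values sit, (the limit of > 20000 nM in this assay, at which 2 of the 3 values shown sit). The steps read an at least 3.8-fold higher number from compound 1 to compound 2 (0.58 log units; beyond the scatter) and an at least 3.8-fold higher number from compound 1 to compound 3 (0.58 log units; beyond the scatter), while the step that the two limits leave unreadable from compound 2 to compound 3 cannot be read.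

Compound 4 `CSc1ncnc2c1c(-c1ccsc1)cn2[C@@H]1O[C@H](CO)[C@@H](O)[C@H]1O` differs from compound 3 in one place: methylsulfanyl in place of dimethylamino on an aromatic carbon. The change brings back a single-atom link to a methyl, as in compound 1, and the steps of an at least 3.8-fold higher number from compound 1 to compound 2 (0.58 log units; beyond the scatter) and an at least 3.8-fold higher number from compound 1 to compound 3 (0.58 log units; beyond the scatter) show that such a link fares better here than methyl or dimethylamino. Compound 4 is expected to give a readable number, so that an at least 2.5-fold lower number from compound 3 to compound 4 (0.39 log units; beyond the scatter) is expected to point toward stronger inhibition. The estimate for compound 4 in this assay is 8000 nM, with a range from 2000 nM to 20000 nM.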

Compound 4, half-maximal inhibitory concentration: > 20000 nM
Compound 4: a limit, no number; the forecaster's own chance of this, stated with the estimate: 35%; at least 2.5-fold (0.39 log units) between middle value and limit.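

In this assay compound 4 gives only a limit, and it joins compounds 2 and 3 there: the limit of > 20000 nM in this assay, at which 3 of the 4 values shown sit. Methylsulfanyl in place of methoxy gives an at least 3.8-fold higher number from compound 1 to compound 4 (0.58 log units; beyond the scatter), so a single-atom link to a methyl does not by itself keep a readable value on this aromatic carbon, and of the four groups only the methoxy of compound 1 gives a number. The steps among compounds 2, 3 and 4 cannot be read.

As far as these compounds go, how compounds 2, 3 and 4 rank beyond the limit stays open. Also open, from the compounds shown here alone, is whether the readable value depends on the oxygen link or on the methyl attached to it, which an ethoxy group, a longer alkoxy chain or a hydroxyl group on the same carbon would test in this assay.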